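Alkoxy chain extension on the anilide of the shared core

The compounds below may be only part of what the source reports. "The series", "measured", "known", "first", "only" and "open" are said of these compounds alone.

Measured so far in an assay on isolated protein (Mus musculus) for inhibition of IL15-IL15 receptor (Homo sapiens), read by resazurin assay, with stated times of 30 min and 2.5 days; a lower number here means a stronger inhibitor, a higher number a weaker inhibitor:
compound 1 `Cn1c(Cc2nn(C)c(=O)c3ccccc23)nnc1SCCCCCCCCCCC(=O)Nc1ccc(Cl)cc1Cl`: 3300 nM
compound 2 `COc1ccc(NC(=O)CCCCCCCSc2nnc(Cc3nn(C)c(=O)c4ccccc34)n2C)cc1`: 3900 nM
compound 3 `Cn1c(Cc2nn(C)c(=O)c3ccccc23)nnc1SCCCCCCCCCCC(=O)Oc1ccc(Cl)cc1Cl`: 8700 nM

Compound 2 stands second highest of the three numbers in this assay; compound 1 sits within the scatter of it, and compound 3 lies beyond the scatter, higher. Going by the values given here, the only step between single-change pairs is a 2.6-fold higher number from compound 1 to compound 3 (0.42 log units; beyond the scatter), a modest change at the carbonyl carbon that does not touch the anilide substituent.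

Compound 4 `CCCOc1ccc(NC(=O)CCCCCCCSc2nnc(Cc3nn(C)c(=O)c4ccccc34)n2C)cc1` differs from compound 2 by ethyl in place of hydrogen on a saturated chain carbon bound to an oxygen on an aromatic ring. Among the compounds with values here, no measured pair tests a change of this kind, so the expectation rests on compound 2 alone. Compound 4 is expected to give about 3900 nM in this assay, with a range of 1500 nM to 10000 nM, a step of no change at the digits printed from compound 2 to compound 4 (within the scatter) that is expected to stay within the scatter.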

Compound 4, half-maximal inhibitory concentration: 1600 nM
Beside the measured number, compound 4's estimate is 2.4-fold (0.39 log units) above it, and the stated range covers the measured number.
By their numbers in this assay, from the lowest: compound 4; then compounds 1 and 2 (each within the scatter of the next); then compound 3.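

In this assay the alkoxy group is not a fixed requirement: the change from 4-methoxyphenyl to 4-propoxyphenyl gives a 2.4-fold lower number from compound 2 to compound 4 (0.39 log units; beyond the scatter) and so brings a modest gain rather than a loss. The saturated chain carbon bound to an oxygen on an aromatic ring therefore accepts an added ethyl, although this rests on a single pair. No supporting measurement accounts for the lower number. As far as these compounds go, whether a butoxy or a longer alkoxy chain extends this gain remains open. So does whether a branched isopropoxy group or a terminal hydroxyl on the chain retains it.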